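A few compounds are considered here, and "the series" means these few. Any claim that something is new, unique, unknown or untested is made for them only; others in the source may bear on it.

Measured in a functional assay on SH-SY5Y cells (Homo sapiens) for cytotoxicity, read by MTT assay, with a stated time of 72 h (a higher number here means a weaker inhibitor, a lower number a stronger inhibitor), so far:
- compound 1 `O=C1c2c[n+]([O-])c3ccccc3c2C(=O)c2c1c1ccccc1n2Cc1cn([C@@H]2C[C@H](O)[C@@H](CO)O2)nn1` at 150 nM
- compound 2 `CN1CCN(CCCCCCn2c3c(c4ccccc42)C(=O)c2c[n+]([O-])c4ccccc4c2C3=O)CC1` at 920 nM

Compound 2 stands higher of the two, and the gap to compound 1 lies beyond the scatter. Compound 3 `O=C1c2c[n+]([O-])c3ccccc3c2C(=O)c2c1c1ccccc1n2Cc1cn(C[C@@H](O)CO)nn1` is compound 2 with one change (1-(2,3-dihydroxypropyl)-1H-1,2,3-triazol-4-yl in place of 5-(4-methylpiperazin-1-yl)pentyl on a saturated chain carbon bound to an aromatic nitrogen). Going by the values given here, no measured pair isolates this change. Compound 1 carries a substituted 1H-1,2,3-triazol-4-yl group on a saturated chain carbon bound to an aromatic nitrogen and gives 150 nM in that form, so a step to a lower number, beyond the scatter, is expected in this assay for compound 3. The estimated step is as follows (a 3.7-fold lower number from compound 2 to compound 3 (0.57 log units; beyond the scatter)). For compound 3 the expected value is 250 nM with an estimated range from 90 nM to 700 nM in this read-out.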

Compound 3, half-maximal inhibitory concentration: > 500 nM
Compound 3: no number, only a limit (the forecaster's own chance of this, stated with the estimate: 3%); middle value at least 2.0-fold (0.30 log units) away from the limit.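

In this assay the reading for compound 3 is a limit and not a number: the limit of > 500 nM in this assay, at which 1 of the 3 values shown sits. With 2,3-dihydroxypropyl in place of 4-hydroxy-5-(hydroxymethyl)oxolan-2-yl on an aromatic nitrogen, the series shows an at least 3.3-fold higher number from compound 1 to compound 3 (0.52 log units; beyond the scatter), so at this position the 1H-1,2,3-triazol-4-yl group alone does not set the value; what it carries matters too. The step against compound 2 cannot be read past the limit.

Still open, from the compounds shown here alone, is how 1-(2,3-dihydroxypropyl)-1H-1,2,3-triazol-4-yl ranks against 5-(4-methylpiperazin-1-yl)pentyl. Also open, going by these compounds, is whether a simple amine or a longer chain on that aromatic nitrogen would stay nearer compound 1.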